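A few compounds are considered here, and "the series" means these few. Any claim that something is new, unique, unknown or untested is made for them only; others in the source may bear on it.

Three compounds share a core built from a benzamide-bearing bicyclic system attached to a phenyl ring that carries an amide or urea. Compound 1 `O=C(Nc1ccc(-n2ccc3c(NC(=O)c4ccccc4)ncnc32)cc1)c1ccc(Cl)c(Cl)c1` holds a 3,4-dichlorophenyl on the carbonyl carbon; in a functional assay on A375P cells (Homo sapiens) for antiproliferative activity, read by MTT assay, with a stated time of 24 h (on this read-out lower numbers stand for stronger inhibition and higher numbers for weaker inhibition), compound 1 gives 2000 nM. Compound 2 `O=C(Nc1ccc(-n2ccc3c(NC(=O)c4ccccc4)ncnc32)cc1)Nc1ccc(Cl)c(C(F)(F)F)c1` carries a (4-chloro-3-(trifluoromethyl)phenyl)amino there, and compound 2 gives 4600 nM. Compound 3 `O=C(Nc1ccc(-n2ccc3c(NC(=O)c4ccccc4)ncnc32)cc1)Nc1cccc(C(F)(F)F)c1` carries a (3-(trifluoromethyl)phenyl)amino, and compound 3 gives 9500 nM, the highest of the three numbers, so it is the weakest inhibitor shown: a 2.1-fold higher number from compound 2 to compound 3 (0.31 log units; beyond the scatter) and a 4.8-fold higher number from compound 1 to compound 3 (0.68 log units; beyond the scatter).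

Compound 4 `O=C(Nc1ccc(-n2ccc3c(NC(=O)c4ccccc4)ncnc32)cc1)Nc1ccc(Cl)c(Cl)c1` arises from compound 3 by 3,4-dichlorophenyl in place of 3-(trifluoromethyl)phenyl on an amide-type nitrogen. Going by the values given here, two measured steps bear on this. Removing a chloro, a 2.1-fold higher number from compound 2 to compound 3 (0.31 log units; beyond the scatter), raised the number modestly, so restoring a chloro should lower it. Compound 2 already holds a chloro beside a trifluoromethyl and sits between compounds 1 and 3. Among the compounds with values here, replacing trifluoromethyl by a second chloro has no direct precedent here, so compound 4 is expected to land near compound 2, and a step of a 2.7-fold lower number from compound 3 to compound 4 (0.43 log units; beyond the scatter) is expected. Compound 4 is therefore estimated at 3500 nM, with a range from 1500 nM to 8000 nM.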

Compound 4, half-maximal inhibitory concentration: 4000 nM
The estimate for compound 4 lay 1.1-fold (0.06 log units) below the measured number, and the stated range covers the measured number.
By their numbers in this assay, from the lowest: compounds 1, 4 and 2 (each within the scatter of the next, the first and the last beyond it); then compound 3.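

In this assay the step of a 2.4-fold lower number from compound 3 to compound 4 (0.38 log units; beyond the scatter) shows that 3,4-dichlorophenyl on the amide-type nitrogen beats 3-(trifluoromethyl)phenyl, while chloro in place of trifluoromethyl on an aromatic carbon gives a 1.2-fold lower number from compound 2 to compound 4 (0.06 log units; within the scatter) and so no readable difference between those two rings. The earlier steps shown here from compound 1 changed the link and the ring together, but a 2.0-fold higher number from compound 1 to compound 4 (0.30 log units; within the scatter) changes only the link, with the 3,4-dichlorophenyl kept, and this swap of the carbonyl-bound ring for its amino form also stays within the scatter. Nothing measured here explains these steps.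

The compounds shown leave open how a ring bearing a methoxy group, an amine or a carboxylic acid would behave on this nitrogen. They also leave open whether a longer chain between the nitrogen and the ring would keep these numbers.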